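This account rests on a few compounds, and the source may have more. Where it says the series, first, only, none or still open, it means among the compounds named here.

Compound 1 `Cc1ccccc1C(=O)Nc1ccc(Nc2ncc(C)c(-c3ccc(OC(F)(F)F)cc3)n2)cc1` was tested in an assay on NIH3T3 cells for inhibition of Sonic hedgehog protein (Mus musculus), read by a luciferase reporter, with a stated time of 48 h (on this read-out lower numbers stand for stronger inhibition and higher numbers for weaker inhibition), where compound 1 gives 42.1 nM. Of the two numbers recorded, this is the higher one; compound 2 `Cc1ccc(-c2cnn(C)c2)cc1NC(=O)c1ccc(Nc2ncc(C)c(-c3ccc(OC(F)(F)F)cc3)n2)cc1` gives 1.2 nM in this assay, a gap that lies beyond the scatter. Compound 3 `Cc1cnc(Nc2ccc(C(=O)NC(C)C)cc2)nc1-c1ccc(OC(F)(F)F)cc1` has not yet been measured in this assay. It is derived from compound 1 by one change: isopropylcarbamoyl in place of ((2-methylphenyl)carbonyl)amino on an aromatic carbon. The group that enters is smaller and has no ring, whereas the group that leaves carries one six-membered aromatic ring of carbon only. Within the data shown here, no measured pair shows this exchange, so its effect can only be anticipated. Compound 3 is therefore expected to give a weaker result, with the step of a 7.1-fold higher number from compound 1 to compound 3 (0.85 log units; beyond the scatter) estimated to run toward higher numbers and beyond the scatter. Compound 3 is accordingly estimated at 300 nM in this assay, within a range from 80 nM to 1500 nM.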

Compound 3, half-maximal inhibitory concentration: 73.1 nM
Compound 3: the middle estimate sits 4.1-fold (0.61 log units) above what was measured; the whole stated range lies above it.
By their numbers in this assay, from the lowest: compound 2; then compounds 1 and 3 (each within the scatter of the next).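

In this assay, isopropylcarbamoyl in place of ((2-methylphenyl)carbonyl)amino gives a 1.7-fold higher number from compound 1 to compound 3 (0.24 log units; within the scatter), so this read-out does not separate the two compounds. At this aromatic carbon, para to a large group, the six-membered aromatic ring of the leaving group is therefore not required to stay in the range of compound 1: a group with no ring and fewer heavy atoms, and with the same count of hydrogen-bond donors and acceptors, serves as well. Nothing available explains why the exchange leaves the number within the scatter.

The compounds shown leave open how far this position tolerates other groups, such as a carboxylic acid, a primary amine or a longer chain like n-butylcarbamoyl. They also do not show whether the amide link itself is needed, which a plain isopropyl group would test.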